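The source may report more compounds than this note shows. Statements on the series, on what has been measured and on what is new or still open speak of the compounds shown alone.

Measured so far:
compound 1 `OC(CCn1nc2c(Br)c(Br)c(Br)c(Br)c2n1)c1ccc(F)cc1`: 0%
compound 2 `OC(CCn1nc2c(Br)c(Br)c(Br)c(Br)c2n1)c1cccc(Cl)c1`: 0%

Both compounds share the same core and differ only in the aromatic ring that sits on a saturated chain carbon bound to an oxygen on a saturated carbon and a saturated chain carbon. In a functional assay on CCRF-CEM cells (Homo sapiens) for antiproliferative activity, read by MTT assay, with a stated time of 48 h, tested at 100 uM (a lower number here means a stronger effect, a higher number a weaker effect of the compound at the concentration tested), compound 1 gives 0% and compound 2 gives 0%, so compound 2 stands level with compound 1. The step of no change at the digits printed from compound 1 to compound 2 (within the scatter) shows that swapping one substituted aromatic ring for another left the read-out untouched. Compound 3 `OC(CCn1nc2c(Br)c(Br)c(Br)c(Br)c2n1)c1ccccc1` is not yet measured. The change from compound 2 to compound 3 is hydrogen in place of chloro on an aromatic carbon. Within the data shown here, the only step available, from compound 1 to compound 2, also altered this aromatic ring, and it produced no movement at all. Since the ring appears insensitive to what it carries and both measured values sit at the floor, no step beyond the scatter is expected here. Compound 3 is therefore estimated at 0%, within 0% to 15%, which means an expected step of no change at the digits printed from compound 2 to compound 3 (within the scatter).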

Compound 3, a percentage reported as activity, at one concentration (the size of the read-out at that concentration, not a potency): 0%
Compound 3: the middle estimate sits on the measured number at the digits printed; the range from low to high includes it.
By their numbers in this assay, from the lowest: compounds 1, 2 and 3 (each within the scatter of the next).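

In this assay the loss of chloro gives no change at the digits printed from compound 2 to compound 3 (within the scatter) and the loss of fluoro gives no change at the digits printed from compound 1 to compound 3 (within the scatter) with hydrogen taking its place in each case. Compound 3 carries a plain phenyl and still gives 0% in this read-out, so neither halogen is needed to hold the value where it stands, and the earlier comparison of one halogen with another could not show that. All three compounds now sit at the bottom end of the scale, which means this single concentration cannot separate them even if they would differ at lower concentrations.

Nothing measured here explains why the ring tolerates these changes. Still open is whether an amine or a carboxylic acid on the aromatic ring, or a longer chain in place of the present one linking the ring to the shared core, would lift the read-out off this value, and how far the activity of these compounds holds up at lower concentrations.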